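A few compounds are considered here, and "the series" means these few. Any claim that something is new, unique, unknown or untested is made for them only; others in the source may bear on it.

In a functional assay (Cavia porcellus) with sulfonylurea receptors; K-ATP channels (Homo sapiens) as the target (on this read-out higher numbers stand for weaker inhibition and lower numbers for stronger inhibition), the three measured compounds gave the following numbers:

compound 1, `CC(O)(C(=O)Nc1ccc(S(=O)(=O)c2cccc(O)c2)cc1)C(F)(F)F`, 18000 nM
compound 2, `CC(O)(C(=O)Nc1ccc(S(=O)(=O)c2ccccc2Cl)cc1)C(F)(F)F`, 2300 nM
compound 3, `Cc1ccccc1S(=O)(=O)c1ccc(NC(=O)C(C)(O)C(F)(F)F)cc1`, 5100 nM

Compound 3 holds the second highest of the three numbers: its nearest neighbour is compound 2, with a 2.2-fold higher number from compound 2 to compound 3 (0.35 log units; beyond the scatter), and its furthest is compound 1, with a 3.5-fold lower number from compound 1 to compound 3 (0.55 log units; beyond the scatter). The step to compound 4, `CC(O)(C(=O)Nc1ccc(S(=O)(=O)c2ccc([N+](=O)[O-])cc2)cc1)C(F)(F)F`, is 4-nitrophenyl in place of 2-methylphenyl on a sulfonyl sulfur. Among the compounds with values here, two measured steps bear on it, since both exchange the group on the same sulfonyl sulfur: a 7.8-fold lower number from compound 1 to compound 2 (0.89 log units; beyond the scatter) and a 3.5-fold lower number from compound 1 to compound 3 (0.55 log units; beyond the scatter). Both were modest. Within the data shown here, no measured compound carries 4-nitrophenyl, so the direction is uncertain. Compound 4 is therefore expected to show a modest change, a 1.8-fold higher number from compound 3 to compound 4 (0.25 log units; within the scatter), with an estimated value of 9000 nM, in a range from 3000 nM to 27000 nM.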

Compound 4, half-maximal inhibitory concentration: > 30000 nM
Compound 4 was reported as a limit (the forecaster's own chance of this, stated with the estimate: 5%); middle value at least 3.3-fold (0.52 log units) away from the limit.
By their numbers in this assay, from the lowest: compound 2; then compound 3; then compound 1. At a limit, above all of these: compound 4.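

Compound 4 is reported only as a limit in this assay, > 30000 nM. Within the data shown here, this exchange on the sulfonyl sulfur raises the number, an at least 5.8-fold higher number from compound 3 to compound 4 (0.76 log units; beyond the scatter) and an at least 13-fold higher number from compound 2 to compound 4 (1.11 log units; beyond the scatter), so the group at this place can carry the read-out to the limit of this assay, whereas the earlier steps there spanned a narrower range. Against the previous highest value, the comparison stays unsettled, an at least 1.6-fold higher number from compound 1 to compound 4 (0.22 log units; that floor lies within the scatter).

Going by these compounds, it remains open whether 4-chlorophenyl or 2-nitrophenyl on this sulfonyl sulfur would give the same rise.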